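Isopropyl in Place of Phenyl on the Shared Core

The source may report more compounds than this note shows. Statements on the series, on what has been measured and on what is new or still open speak of the compounds shown alone.

Two compounds carry the shared core with a urea-linked dichloropyridine or chloromethoxypyridine. Compound 1 `Cn1ncc2c(-c3ccccc3)cc(NNC(=O)Nc3cc(Cl)nc(Cl)c3)nc21` was measured in an assay on isolated protein for binding affinity to sphingosine 1-phosphate receptor 2 (Homo sapiens), read by surface plasmon resonance (on this read-out higher numbers stand for weaker binding and lower numbers for tighter binding), where compound 1 gives 1020 nM. Compound 2 `COc1ccc(-c2cc(NNC(=O)Nc3cc(Cl)nc(OC)c3)nc3c2cnn3C)cc1` in this assay gives 1980 nM. The two numbers lie within the scatter of each other, so compound 1 cannot be placed ahead of or behind compound 2; compound 1 simply holds the lower of the two numbers shown, with compound 2 as its only neighbour.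

Going by the values given here, no pair of measured compounds differs in a single place, so the size of any one change has not been seen. Compound 3 `CC(C)c1cc(NNC(=O)Nc2cc(Cl)nc(Cl)c2)nc2c1cnn2C` differs from compound 1 as follows: isopropyl in place of phenyl on an aromatic carbon. Among the compounds with values here, with no measured single step to lean on, the expectation for this assay is a modest step from compound 1 toward a higher number, of a size that may not clear the scatter.

The expected step of a 2.0-fold higher number from compound 1 to compound 3 (0.29 log units; within the scatter) is small. Compound 3 is estimated at 2000 nM, with a range from 700 nM to 6000 nM.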

Compound 3, dissociation constant: 780 nM
Estimate against measurement, compound 3: 2.6-fold (0.41 log units) above; the range from low to high includes it.
By their numbers in this assay, from the lowest: compounds 3, 1 and 2 (each within the scatter of the next, the first and the last beyond it).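

Going by these compounds alone, the swap at this position gives the first single-place step: a 1.3-fold lower number from compound 1 to compound 3 (0.12 log units; within the scatter). In this assay, compound 3 at 780 nM and compound 1 at 1020 nM therefore cannot be told apart, even though isopropyl, with 3 heavy atoms and no ring, enters where phenyl, with 6 heavy atoms and a six-membered aromatic ring, leaves. At this position, then, an aromatic ring is not required for binding in the range seen so far, at least with the urea-linked dichloropyridine held constant, and nothing on hand bears on why the two groups read alike.

Compound 2 differs from compound 1 and from compound 3 in more than one place, so the steps involving it cannot be read, and the separate contributions of its methoxy groups stay unresolved. Also open, as far as these compounds go, is how far this position tolerates other groups: a methyl, a cyclohexyl ring, a longer alkyl chain or an amine would show whether the read-out stays this flat or moves beyond the scatter.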